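From Pyridin-2-yl to Ethyl on the Shared Core

The compounds below may be only part of what the source reports. "The series", "measured", "known", "first", "only" and "open" are said of these compounds alone.

In a functional assay on MCF7 cells (Homo sapiens) for antiproliferative activity, read by MTT assay, with a stated time of 48 h (on this read-out higher numbers stand for weaker inhibition and lower numbers for stronger inhibition), compound 1 `COc1ccc(N2CCN(C(=O)/C=C/c3ccc(O)c(O)c3)CC2)cc1` gives 0.52 ug/mL, compound 2 `Cc1ccc(N2CCN(C(=O)/C=C/c3ccc(O)c(O)c3)CC2)c(C)c1` gives 0.78 ug/mL and compound 3 `O=C(/C=C/c1ccc(O)c(O)c1)N1CCN(c2ccccn2)CC1` gives 1.82 ug/mL, the highest number of the three. Compound 4 `CCN1CCN(C(=O)/C=C/c2ccc(O)c(O)c2)CC1` differs from compound 3 by ethyl in place of pyridin-2-yl on an amine nitrogen in a ring. For the measured compounds named here, two measured steps bear on this place: a 3.5-fold higher number from compound 1 to compound 3 (0.54 log units; beyond the scatter) and a 2.3-fold higher number from compound 2 to compound 3 (0.37 log units; beyond the scatter), both modest and beyond the scatter. Going by the values given here, each of them exchanges one ring-bearing group for another, and no measured compound has a group without a ring there, so the data cover this change only loosely. The expected step is a 1.9-fold higher number from compound 3 to compound 4 (0.28 log units; within the scatter), towards weaker inhibition. For compound 4 the estimated value is 3.5 ug/mL, with an expected range from 1.2 ug/mL to 10 ug/mL.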

Compound 4, half-maximal inhibitory concentration: 2.06 ug/mL
Estimate against measurement, compound 4: 1.7-fold (0.23 log units) above; the measured number falls inside the stated range.
By their numbers in this assay, from the lowest: compounds 1 and 2 (each within the scatter of the next); then compounds 3 and 4 (each within the scatter of the next).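

Losing the ring on the amine nitrogen changes little from pyridin-2-yl in this assay (a 1.1-fold higher number from compound 3 to compound 4 (0.05 log units; within the scatter)), so a ring there is not needed to match compound 3. The two groups that do stand apart are 2,4-dimethylphenyl (a 2.6-fold higher number from compound 2 to compound 4 (0.42 log units; beyond the scatter)) and 4-methoxyphenyl (a 4.0-fold higher number from compound 1 to compound 4 (0.60 log units; beyond the scatter)), which separates them from ethyl as well as from pyridin-2-yl. No measurement offered here explains this difference. From the compounds shown here alone, it remains open whether an unsubstituted phenyl would side with those two groups, and whether a longer chain ending in an amine would stay level with ethyl.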